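A few compounds are considered here, and "the series" means these few. Any claim that something is new, unique, unknown or untested is made for them only; others in the source may bear on it.

Measured compounds:
- compound 1, `C=C1CC[C@@H]2[C@](C)(COC(C)=O)[C@H](OC(C)=O)CC[C@@]2(C)[C@@H]1C/C=C1/C(=O)OC[C@H]1OC(C)=O`, 11.6 uM
- compound 2, `C=C1CC[C@@H]2[C@](C)(CO)[C@H](OC(C)=O)CC[C@@]2(C)[C@@H]1C/C=C1/C(=O)OC[C@H]1OC(C)=O`, 11.7 uM
- compound 3, `C=C1CC[C@@H]2[C@](C)(CO[Si](C)(C)C(C)(C)C)[C@H](O)CC[C@@]2(C)[C@@H]1C/C=C1/C(=O)OC[C@H]1O`, 40.7 uM

All three were tested in a functional assay on KB cells (Homo sapiens) for cytotoxicity, read by sulforhodamine B assay; on this read-out higher numbers stand for an effect only at larger amounts of compound and lower numbers for an effect already at smaller amounts. Compound 2 and compound 1 differ in one place only: acetyl in place of hydrogen on an oxygen on a saturated carbon. That change left the read-out essentially unchanged, a 1.0-fold lower number from compound 2 to compound 1 (0.00 log units; within the scatter). Compound 3 stands apart, with the highest number of the three; how its core differs from the core of compound 2 is not broken down here, the two differ in more than one place.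

Compound 4, `C=C1CC[C@@H]2[C@](C)(CO[Si](C)(C)C(C)(C)C)[C@H](OC(C)=O)CC[C@@]2(C)[C@@H]1C/C=C1/C(=O)OC[C@H]1O`, has not yet been measured. It differs from compound 3 by acetyl in place of hydrogen on an oxygen on a saturated carbon. Within the data shown here, this is the same kind of change as the one from compound 2 to compound 1, but not at the same spot: in the earlier pair the oxygen sat on a saturated carbon whose other neighbour was a saturated chain carbon, whereas here the oxygen sits on a saturated carbon whose other neighbour is a saturated ring carbon.

Among the measured compounds shown here, since the only comparable change on hand, a 1.0-fold lower number from compound 2 to compound 1 (0.00 log units; within the scatter), fell within the scatter, a similarly small step is expected here, a 1.2-fold lower number from compound 3 to compound 4 (0.07 log units; within the scatter). Compound 4 is therefore estimated at 35 uM in this assay, with a likely range from 15 uM to 80 uM. The measurement will show whether that expectation holds.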

Compound 4, concentration for half-maximal effect: 11.2 uM
Compound 4: the middle estimate sits 3.1-fold (0.49 log units) above what was measured; measured number below the stated range.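

In this assay, hydroxy to acetoxy on a saturated carbon whose other neighbour is a saturated ring carbon gave a clear step, a 3.6-fold lower number from compound 3 to compound 4 (0.56 log units; beyond the scatter). The same kind of change therefore does not carry a single size of effect from one core to another in this series, and a flat result on one core did not predict the result on the other: the same change on two cores in this assay, a 1.0-fold lower number (0.00 log units; within the scatter) from compound 2 to compound 1 and a 3.6-fold lower number (0.56 log units; beyond the scatter) from compound 3 to compound 4, 3.6-fold (0.56 log units) apart, beyond the scatter of two such steps. This shows only that the size of the step depends on its setting; the two pairs differ both in the spot that was changed and in the rest of the molecule, so they cannot tell which of these sets the size, and two pairs give no general rule for this change.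

The compounds shown leave open whether a longer acyl chain such as butanoyl, or a benzoyl group, in place of acetyl at this oxygen would give a step of similar size. They also leave open what would happen if the hydroxy that remains in compound 4 were acetylated too, and whether the step seen here would appear on a core carrying the free hydroxymethyl group of compound 2.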